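A few compounds are considered here, and "the series" means these few. Any claim that something is new, unique, unknown or untested is made for them only; others in the source may bear on it.

The measured compounds:
compound 1 `Nc1nccc(-c2ccc3nc(C4COc5ccc(F)cc5C4)oc3c2)n1` 15 nM
compound 2 `Cc1[nH]ncc1-c1ccc2nc(C3COc4ccccc4C3)oc2c1` 9 nM
compound 3 `Nc1nccc(-c2ccc3nc(C4COc5ccc(F)cc5C4)[nH]c3c2)n1` 6 nM

In an assay on isolated protein for inhibition of Rho-associated protein kinase 2 (Homo sapiens) (on this read-out lower numbers stand for stronger inhibition and higher numbers for weaker inhibition), compound 3 gives 6 nM, the lowest of the three numbers. Compound 2, at 9 nM, lies within the usual scatter of that figure, so the two cannot be told apart; compound 1, at 15 nM, lies beyond it. Compound 4 `COc1ccc2c(c1)CC(c1nc3ccc(-c4ccnc(N)n4)cc3[nH]1)CO2` differs from compound 3 in one place: methoxy in place of fluoro on an aromatic carbon. Among the compounds with values here, no pair of measured compounds shows this change, so no measured step guides the expectation. The step from compound 3 to compound 4 in this assay is expected to be small, a 1.7-fold higher number from compound 3 to compound 4 (0.22 log units; within the scatter), and could fall in either direction within the scatter. Compound 4 is therefore estimated at 10 nM, with a range from 3 nM to 30 nM.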

Compound 4, half-maximal inhibitory concentration: 2 nM
Estimate against measurement, compound 4: 5.0-fold (0.70 log units) above, and the stated range ends above it.
By their numbers in this assay, from the lowest: compound 4; then compounds 3, 2 and 1 (each within the scatter of the next, the first and the last beyond it).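

In this assay methoxy in place of fluoro on this aromatic carbon brings a 3.0-fold lower number from compound 3 to compound 4 (0.48 log units; beyond the scatter) and so gives the first measured sign that the group here affects the read-out. The earlier compounds shown here held no step at this position, which now accepts methoxy with no loss. No available evidence explains the gain. Going by these compounds, whether it is particular to methoxy stays open, since an ethoxy group, a hydroxyl or an amine on the same carbon could behave differently. Also open, on these data alone, is whether the same change would act alike on the core of compound 1 or compound 2.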